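A few compounds are considered here, and "the series" means these few. Any claim that something is new, unique, unknown or untested is made for them only; others in the source may bear on it.

In a functional assay on T47D cells (Homo sapiens) for inhibition, read by CCK-8 assay, with a stated time of 72 h, tested at 10 uM (on this read-out lower numbers stand for less inhibition of growth and higher numbers for more inhibition of growth at the one concentration tested), three compounds have been measured so far. Compound 1 (`CN(C)C(=O)c1cc2cnc(Nc3ccc(N)cn3)nc2n1C1CCCC1`) gives 61.1%. Compound 2 (`CN(C)C(=O)c1cc2cnc(Nc3ccc(NC(=O)C4(C(=O)Nc5cccc(O)c5)CC4)cc3)nc2n1C1CCCC1`) gives 83.7%. Compound 3 (`Nc1ccc(NC(=O)C2(C(=O)Nc3ccc(F)cc3)CC2)cc1F`) gives 30.4%. Compound 2 therefore stands highest of the three, and its value lies beyond the scatter from both of the others, with compound 1 the nearer of the two.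

The next compound, compound 4 (`CN(C)C(=O)c1cc2cnc(Nc3ccc(NC(=O)C4(C(=O)Nc5ccc(Cl)c(C(F)(F)F)c5)CC4)cc3)nc2n1C1CCCC1`), differs from compound 2 in one place: 4-chloro-3-(trifluoromethyl)phenyl stands in place of 3-hydroxyphenyl on an amide-type nitrogen. The counted difference is 4-chloro-3-(trifluoromethyl)phenyl in place of 3-hydroxyphenyl on an amide-type nitrogen.

Among the compounds with values here, no pair of measured compounds differs in one place, so the data give no direct measure of what this exchange does. Compound 4 keeps the core shared by compound 1 and compound 2, which compound 3 lacks. The expectation therefore starts from compound 2 at 83.7%, and the wide range reflects the missing comparison. The expected change is a number 3.7 percentage points lower from compound 2 to compound 4 (within the scatter), a small fall that is estimated to stay within the scatter. For compound 4 the estimated value is 80%, with an expected range from 62% to 95%.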

Compound 4, percent growth inhibition at one concentration: 55.8%
The estimate for compound 4 lay 24.2 percentage points above the measured number; the measured number lies below the stated range.
By their numbers in this assay, from the lowest: compound 3; then compounds 4 and 1 (each within the scatter of the next); then compound 2.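

In this assay, putting 4-chloro-3-(trifluoromethyl)phenyl in place of 3-hydroxyphenyl on an amide-type nitrogen gives a number 27.9 percentage points lower from compound 2 to compound 4 (beyond the scatter). Within the data shown here, this is the first direct reading at this position, and it shows that, with the rest of the molecule unchanged, the group on this nitrogen can alter growth inhibition by more than the scatter, and that this exchange lowers it. The group that leaves has 1 hydrogen-bond donor, 1 hydrogen-bond acceptor and 7 heavy atoms, while the group that enters has 0 hydrogen-bond donors, 0 hydrogen-bond acceptors and 11 heavy atoms, but nothing measured here ties the fall to any of these differences.

The compounds shown leave open whether the chloro or the trifluoromethyl group accounts for the fall, as 4-chlorophenyl and 3-(trifluoromethyl)phenyl do not appear among them. They also leave open whether the hydroxyl of compound 2 can be exchanged for another group, such as an amine in 3-aminophenyl or a carboxylic acid in 3-carboxyphenyl, without a comparable change.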